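This account rests on a few compounds, and the source may have more. Where it says the series, first, only, none or still open, it means among the compounds named here.

The three measured compounds share one core and differ only in the acyl group on the ring nitrogen. Compound 1 `CCC(=O)N1C/C(=C\c2cc(OC)c(OC)c(OC)c2)C(=O)/C(=C/c2cc(OC)c(OC)c(OC)c2)C1` gives 1700 nM in a functional assay on NCI-H1975 cells (Homo sapiens) for cytotoxicity, read by MTT assay, with a stated time of 72 h; a higher number here means a weaker inhibitor, a lower number a stronger inhibitor. Compound 2 `COc1cc(/C=C2\CN(C(=O)c3ccccc3F)C/C(=C\c3cc(OC)c(OC)c(OC)c3)C2=O)cc(OC)c1OC` gives 1400 nM in this assay, and compound 3 `COc1cc(/C=C2\CN(C(=O)C(C)C)C/C(=C\c3cc(OC)c(OC)c(OC)c3)C2=O)cc(OC)c1OC` gives 1900 nM in this assay. Compound 3 has the highest of the three numbers, but every gap to it is within the scatter: a 1.1-fold higher number from compound 1 to compound 3 (0.05 log units; within the scatter), and a 1.4-fold higher number from compound 2 to compound 3 (0.13 log units; within the scatter). The remaining pair behaves the same way, with a 1.2-fold lower number from compound 1 to compound 2 (0.08 log units; within the scatter).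

Compound 4 `COc1cc(/C=C2\CN(C(=O)CCC(=O)O)C/C(=C\c3cc(OC)c(OC)c(OC)c3)C2=O)cc(OC)c1OC` is not yet measured. Its difference from compound 3 is 2-carboxyethyl in place of isopropyl on a carbonyl carbon. The measured steps that bear on this place are the three just given, all changes of the group on the same carbonyl carbon, and all within the scatter. None of them, however, brings in a hydrogen-bond donor or acceptor, so the data say nothing about that part of the change. On the steps shown, compound 4 is expected to stay close to compound 3, with a 1.3-fold higher number from compound 3 to compound 4 (0.10 log units; within the scatter) in this assay, though with wider uncertainty than the earlier steps. Compound 4 is therefore estimated at 2400 nM, within a range from 900 nM to 6500 nM.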

Compound 4, half-maximal inhibitory concentration: > 60000 nM
Compound 4: no number, only a limit; the forecaster's own chance of this, stated with the estimate: 5%; middle value at least 25-fold (1.39 log units) from the limit.
By their numbers in this assay, from the lowest: compounds 2, 1 and 3 (each within the scatter of the next). At a limit, above all of these: compound 4.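

Among the earlier compounds, changing the group on this carbonyl carbon, whose other neighbour is the amide-type nitrogen in a ring, between ethyl, isopropyl and 2-fluorophenyl moved nothing beyond the scatter, so the place looked tolerant of change. In this assay the 2-carboxyethyl group breaks that picture, with an at least 31-fold higher number from compound 3 to compound 4 (1.49 log units; beyond the scatter) for the replacement of isopropyl and an at least 42-fold higher number from compound 2 to compound 4 (1.63 log units; beyond the scatter) for the replacement of 2-fluorophenyl, and the closest comparison gives an at least 35-fold higher number from compound 1 to compound 4 (1.54 log units; beyond the scatter) for carboxy in place of hydrogen on the saturated chain, so this position is not indifferent to what it carries. The value of compound 4 is a limit of the assay and not a number: the limit of > 60000 nM in this assay, at which 1 of the 4 values shown sits.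

The compounds shown leave open whether the free carboxylic acid is what matters or whether a methyl ester or a primary amine at the end of the same chain would stay with compound 1, compound 2 and compound 3. They also leave open how a longer chain ending in a carboxylic acid would behave at this place.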